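This account rests on a few compounds, and the source may have more. Where it says the series, first, only, none or still open, it means among the compounds named here.

Among the measured compounds shown here, in a functional assay on BT-549 cells (Homo sapiens) for cytotoxicity, read by sulforhodamine B assay, with a stated time of 72 h (a higher number here means a weaker inhibitor, a lower number a stronger inhibitor), compound 2 `CCS(=O)(=O)Nc1cc(-c2ccc3ncnc(Nc4ccc(OC)cc4)c3c2)cnc1OC` gives 1880 nM, the lowest of the two numbers so far, while compound 1 `CCS(=O)(=O)Nc1cc(-c2ccc3ncnc(Nc4ccc(F)cc4)c3c2)cnc1OC` gives 3120 nM; the step of a 1.7-fold lower number from compound 1 to compound 2 (0.22 log units; within the scatter) is within the scatter, so the two stand level. Compound 3 `CCS(=O)(=O)Nc1cc(-c2ccc3ncnc(Nc4cccc(C(=O)OC)c4)c3c2)cnc1OC` differs from compound 2 by 3-(methoxycarbonyl)phenyl in place of 4-methoxyphenyl on a nitrogen on an aromatic ring. For the measured compounds named here, the only measured step, from compound 1 to compound 2, swaps one group for another on the same ring and yields no change beyond the scatter, so it bears on the present change only loosely: it shows that this ring tolerates one such swap without a clear shift, but says nothing about a methoxycarbonyl group. Compound 3 is therefore expected to stay near compound 2 in this assay, with a step of about a 1.3-fold higher number from compound 2 to compound 3 (0.12 log units; within the scatter) toward a somewhat higher number. The estimate for compound 3 is 2500 nM, within a range of 800 nM to 8000 nM.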

Compound 3, half-maximal inhibitory concentration: 1080 nM
For compound 3 the middle estimate is 2.3-fold (0.36 log units) above the measured one; low and high end bracket the measured number.
By their numbers in this assay, from the lowest: compounds 3, 2 and 1 (each within the scatter of the next, the first and the last beyond it).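

In this assay, a 1.7-fold lower number from compound 2 to compound 3 (0.24 log units; within the scatter) leaves compound 3 and compound 2 level, so this position on the nitrogen takes 3-(methoxycarbonyl)phenyl, with its added double bond outside the ring and its second acceptor, with no shift beyond the scatter. Measured against the 4-fluorophenyl group, the same substituent gives a 2.9-fold lower number from compound 1 to compound 3 (0.46 log units; beyond the scatter), the first step among these compounds to clear the scatter, though only modestly. Nothing measured here accounts for either step.

The compounds shown do not separate the identity of the group from its place on the ring, as compound 3 differs from compound 2 in both. Also open, as far as these compounds go, is whether a carboxylic acid or an amide in place of the methoxycarbonyl group would keep the number of compound 3.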